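The source may report more compounds than this note shows. Statements on the series, on what has been measured and on what is new or still open speak of the compounds shown alone.

Values in a functional assay for antagonist activity at 5-hydroxytryptamine receptor 4 (Cavia porcellus) (a lower number here means a less potent compound, a higher number a more potent compound, by a factor of ten per unit of this negative logarithm), for the measured members of the series:

compound 1 `CC(C)n1c(=O)n(C(=O)NCCN2CCN(C)CC2)c2ccccc21`: < 6
compound 2 `COc1ccc2c(c1)n(C(=O)NCCN1CCN(C)CC1)c(=O)n2C(C)C`: < 6
compound 3 `CC(C)n1c(=O)n(C(=O)NCCCN2CCN(C)CC2)c2ccccc21`: < 6

Compound 1 stands at a limit of the assay, not at a number. The same holds for compound 2, and for compound 3. Accordingly the two changes made from compound 1 give a step that the two limits leave unreadable from compound 1 to compound 2 and a step that the two limits leave unreadable from compound 1 to compound 3, and nothing about their size can be read, as the limit of < 6 in this assay, at which 3 of the 3 values shown sit, records.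

Compound 4 `CCCn1c(=O)n(C(=O)NCCN2CCN(C)CC2)c2ccccc21` is the next member. Its change from compound 1 is propyl in place of isopropyl on an aromatic nitrogen. Among the measured compounds shown here, no measured step touches this position; the only known steps from compound 1 are the two unreadable ones just named. With compound 1 itself at the limit, no direction can be taken from them, and a result at the limit again is the most likely outcome in this assay.

Compound 4 is therefore expected at 5.5, within 4.5 to 6.3. The expected step from compound 1 to compound 4 is a step that the limit leaves unreadable from compound 1 to compound 4, which is no more than the scatter.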

Compound 4, negative logarithm of the antagonist equilibrium constant: < 6
Compound 4: no number, only a limit; the forecaster's own chance of this, stated with the estimate: 80%; the middle value does not contradict the limit.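

In this assay compound 4 gives < 6, a limit and not a number. Compound 1 also stands at a limit, so no step can be read between compound 1 and compound 4. The size and direction of every change shown remain open, with all values resting on one limit: the limit of < 6 in this assay, at which 4 of the 4 values shown sit.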